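A few compounds are considered here, and "the series" means these few. Any claim that something is new, unique, unknown or untested is made for them only; others in the source may bear on it.

Measured so far in an ADME assay (liver) for metabolic stability, with Liver microsome (Rattus norvegicus) as the target, using microsomes and NADPH, with a stated time of 30 min, at 37 degrees C, tested at 1 uM (a lower number here means slower removal, a higher number faster removal of the compound), are three compounds:
- compound 1 `CC(C)Nc1nc(S(=O)(=O)c2ccc(N)nc2)ccc1-c1ccc(C(C)(O)C(F)(F)F)cn1` gives 62 mL.min-1.g-1
- compound 2 `CC(O)(c1ccc(-c2ccc(S(=O)(=O)c3ccc(N)nc3)nc2Nc2ccccc2)nc1)C(F)(F)F` gives 100 mL.min-1.g-1
- compound 3 `CC(O)(c1ccc(-c2ccc(S(=O)(=O)c3ccc(N)nc3)nc2NCc2ccccc2)nc1)C(F)(F)F` gives 114 mL.min-1.g-1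

Compound 3 cannot be told apart from the other two, since a 1.8-fold higher number from compound 1 to compound 3 (0.26 log units; within the scatter) and a 1.1-fold higher number from compound 2 to compound 3 (0.06 log units; within the scatter) are both steps within the scatter.

Compound 4 `CC(O)(c1ccc(-c2ccc(S(=O)(=O)c3ccc(N)nc3)nc2Nc2cccnc2)nc1)C(F)(F)F` has pyridin-3-yl in place of benzyl on a nitrogen on an aromatic ring. The other measured swap on that nitrogen, a 1.6-fold higher number from compound 1 to compound 2 (0.21 log units; within the scatter) as well, stayed within the scatter. Within the data shown here, no measured compound carries pyridin-3-yl, so this guide is indirect.

No step beyond the scatter is expected in this assay and the estimated 1.4-fold lower number from compound 3 to compound 4 (0.15 log units; within the scatter) stays inside it. Compound 4 is expected to give 80 mL.min-1.g-1 with an estimated range from 45 mL.min-1.g-1 to 130 mL.min-1.g-1 for now.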

Compound 4, intrinsic clearance in microsomes: 142 mL.min-1.g-1
Compound 4: the middle estimate sits 1.8-fold (0.25 log units) below what was measured; the whole stated range lies below it.
By their numbers in this assay, from the lowest: compounds 1, 2, 3 and 4 (each within the scatter of the next, the first and the last beyond it).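

In this assay, pyridin-3-yl, whose aromatic ring holds a nitrogen, cannot be told apart from the carbon-only rings on this nitrogen: both a 1.2-fold higher number from compound 3 to compound 4 (0.10 log units; within the scatter) and a 1.4-fold higher number from compound 2 to compound 4 (0.15 log units; within the scatter) stay within the scatter. Among these compounds, only the comparison with the isopropyl compound, a 2.3-fold higher number from compound 1 to compound 4 (0.36 log units; beyond the scatter) as a modest step, passes beyond the scatter, the first step at this position to do so. Nothing available explains why these numbers fall as they do.

Still open, as far as these compounds go, is how a longer alkyl chain or a cyclohexyl ring in place of isopropyl would compare, and whether an amine on the aromatic ring would change the number.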